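A few compounds are considered here, and "the series" means these few. Any claim that something is new, unique, unknown or untested is made for them only; others in the source may bear on it.

Measured so far:
Compound 1 `COc1ccc(CNC(=O)CSc2nc3ccc(NC(C)=O)cc3s2)cc1` gives 11200 nM in a functional assay on HepG2 cells (Homo sapiens) for cytotoxicity, read by MTT assay, with a stated time of 48 h; on this read-out higher numbers stand for weaker inhibition and lower numbers for stronger inhibition.
Compound 2 `COc1ccc(CNC(=O)CSc2nc3ccc(NC(=O)c4ccc([N+](=O)[O-])cc4)cc3s2)cc1` reaches only a limit of the assay, > 100000 nM, in this assay.

Compound 2 therefore stands without a number: it sits at the limit of > 100000 nM in this assay, at which 1 of the 2 values shown sits, and the step of an at least 8.9-fold higher number from compound 1 to compound 2 (0.95 log units; beyond the scatter) is itself known only as a bound. Compound 3 `COc1ccc(CNC(=O)CSc2nc3ccc(NC(=O)c4ccccc4OC)cc3s2)cc1` is not yet measured. It differs from compound 2 by 2-methoxyphenyl in place of 4-nitrophenyl on a carbonyl carbon. Within the data shown here, the one measured step that bears on an aryl group on this carbonyl carbon is an at least 8.9-fold higher number from compound 1 to compound 2 (0.95 log units; beyond the scatter), which carried the series from a measured number to the limit. Compound 3 keeps an aryl group there, so a return to the level of compound 1 is not expected, while a number just inside the measurable range is plausible. The step expected is an at least 1.6-fold lower number from compound 2 to compound 3 (0.22 log units; that floor lies within the scatter), a direction that cannot be checked against a bound. The estimate for compound 3 is 60000 nM, with a range from 15000 nM to 200000 nM.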

Compound 3, half-maximal inhibitory concentration: 2100 nM
Compound 3: the middle estimate sits 29-fold (1.46 log units) above what was measured; measured number outside the range, below it.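

In this assay, an aryl group on this carbonyl carbon does not by itself carry the series to the limit: 2-methoxyphenyl in place of 4-nitrophenyl gives an at least 47-fold lower number from compound 2 to compound 3 (1.67 log units; beyond the scatter), so the outcome depends on which aryl group is present. Against the methyl of the starting amide, 2-methoxyphenyl gives a 5.3-fold lower number from compound 1 to compound 3 (0.73 log units; beyond the scatter), so this position can move the number in either direction, and compound 3 has the lowest number of the series so far. Compound 2 remains a limit of the assay and not a number, so the larger step is only a bound: the limit of > 100000 nM in this assay, at which 1 of the 3 values shown sits.

The two aryl groups differ both in the substituent and in where it stands on the ring, and these two changes remain unseparated. Going by these compounds, how a phenyl ring carrying an amine or a carboxylic acid, or a longer chain in place of methyl, would read here remains open.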